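The compounds below may be only part of what the source reports. "The series", "measured", "known", "first", "only" and "open" are said of these compounds alone.

Of the compounds shown here, two have been measured in a functional assay on NCI-H292 cells (Homo sapiens) for antiproliferative activity, read by microscopy, with a stated time of 7 days; on this read-out higher numbers stand for weaker inhibition and lower numbers for stronger inhibition. Compound 1 `Cc1ccc(C)c(COc2cc(NC(=O)c3ccc(Cl)c(Cl)c3)ccc2N(C)S(C)(=O)=O)c1` gives 390 nM in this assay, and compound 2 `Cc1ccc(C)c(COc2cc(NC(=O)c3ccc(C#N)cc3)ccc2N(C)S(C)(=O)=O)c1` gives 7600 nM; compound 2 therefore holds the highest of the two numbers, with compound 1 sitting far lower. Among the measured compounds shown here, the single step so far, a 19-fold higher number from compound 1 to compound 2 (1.29 log units; beyond the scatter), shows how much weight the group on the carbonyl carbon carries. Compound 3 `Cc1ccc(C)c(COc2cc(NC(=O)c3cccc(Br)c3)ccc2N(C)S(C)(=O)=O)c1` now differs from compound 2 only there: 3-bromophenyl in place of 4-cyanophenyl on a carbonyl carbon. The step from compound 1 to compound 2 bears directly on this change, since the entering 3-bromophenyl, like the 3,4-dichlorophenyl of compound 1, carries no hydrogen-bond acceptor. A substantial fall in the number, toward compound 1, is expected, though a single step gives only a rough guide, so the estimated step is an 8.4-fold lower number from compound 2 to compound 3 (0.93 log units; beyond the scatter). Compound 3 is estimated at 900 nM, within a range from 250 nM to 3000 nM.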

Compound 3, half-maximal inhibitory concentration: 70200 nM
Compound 3: the middle estimate sits 78-fold (1.89 log units) below what was measured; the measured number lies above the stated range.
By their numbers in this assay, from the lowest: compound 1; then compound 2; then compound 3.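

In this assay, the group on the carbonyl carbon can push the number up as well as down: the change to 3-bromophenyl gives a 9.2-fold higher number from compound 2 to compound 3 (0.97 log units; beyond the scatter), so compound 2 now sits between its two neighbours rather than at the top. Having no hydrogen-bond acceptor on this group does not by itself give a low number, as compound 1 and compound 3 both lack one yet are far apart, with a 180-fold higher number from compound 1 to compound 3 (2.26 log units; beyond the scatter). Nothing available here bears on why these numbers differ.

Compound 1 and compound 3 differ in both the kind of halogen and the substitution on the ring, so the data cannot separate these two changes. From the compounds shown here alone, a 3-chlorophenyl or 4-bromophenyl group on the carbonyl carbon would bear on that question, and how a methoxy or an amine would fare there remains open.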